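The source may report more compounds than this note shows. Statements on the series, on what has been measured and on what is new or still open speak of the compounds shown alone.

Measured so far:
compound 1, `CCC(C)CN[C@H](c1cc(C(F)(F)F)ccc1N1CCN(C(=O)CCc2ccc(Cl)cc2Cl)CC1)C(C)CC`: 2800 nM
compound 2, `CCC(C)[C@H](NC(=O)OC)c1cc(C(F)(F)F)ccc1N1CCN(C(=O)CCc2ccc(Cl)cc2Cl)CC1`: 2400 nM

In an assay on HEK293 cells for displacement of a labelled ligand from Melanocortin receptor 4 (Homo sapiens) (on this read-out higher numbers stand for weaker inhibition and lower numbers for stronger inhibition), compound 2 gives 2400 nM, the lowest of the two numbers; its nearest neighbour is compound 1, which gives 2800 nM; the step of a 1.2-fold lower number from compound 1 to compound 2 (0.07 log units; within the scatter) is within the scatter, so the two compounds cannot be ordered. The step to compound 3, `CC(C)C[C@H](NC(=O)CN)c1cc(C(F)(F)F)ccc1N1CCN(C(=O)CCc2ccc(Cl)cc2Cl)CC1`, is 1-(((aminomethyl)carbonyl)amino)-3-methylbutyl in place of 1-((methoxycarbonyl)amino)-2-methylbutyl on an aromatic carbon. Among the measured compounds shown here, only one measured step exists, that from compound 1 to compound 2, and it concerns a change on the amine nitrogen, not the two changes that enter here; it offers no direct guide, and its size was small. The author therefore expects no step beyond the scatter for compound 3, an estimated 1.1-fold lower number from compound 2 to compound 3 (0.04 log units; within the scatter). Compound 3 is thus estimated at 2200 nM, with a range from 600 nM to 8000 nM.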

Compound 3, inhibition constant: 19 nM
The estimate for compound 3 lay 120-fold (2.06 log units) above the measured number; measured number outside the range, below it.
By their numbers in this assay, from the lowest: compound 3; then compounds 2 and 1 (each within the scatter of the next).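

In this assay, the group on this aromatic carbon, ortho to a large group and meta to a trifluoromethyl group, proves able to move the number far more than the earlier pair suggested. The earlier change stayed within the scatter, with a 1.2-fold lower number from compound 1 to compound 2 (0.07 log units; within the scatter), whereas 1-(((aminomethyl)carbonyl)amino)-3-methylbutyl gives a 130-fold lower number from compound 2 to compound 3 (2.10 log units; beyond the scatter) and a 150-fold lower number from compound 1 to compound 3 (2.17 log units; beyond the scatter). Nothing available explains why this change has so large an effect.

The entering group differs from the one it replaces in both the acyl part on the nitrogen and the branching of the butyl chain, so the compounds shown do not tell which of the two carries the step. Also open, from the compounds shown here alone, is whether the aminomethyl group could give way to an aminoethyl group, a dimethylaminomethyl group or a carboxylic acid with a similar result.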